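A few compounds are considered here, and "the series" means these few. Any claim that something is new, unique, unknown or untested is made for them only; others in the source may bear on it.

Measured compounds:
compound 1 `Cc1ccc(NS(=O)(=O)c2ccc(N3CCNC3=O)cc2)cc1` — 480 nM
compound 2 `CCCCc1ccc(NS(=O)(=O)c2ccc(N3CCNC3=O)cc2)cc1` — 610 nM
compound 3 `CCCCCCCc1ccc(NS(=O)(=O)c2ccc(N3CCNC3=O)cc2)cc1` — > 1000 nM

All three were read in a functional assay on HT-29 cells (Homo sapiens) for antiproliferative activity, read by sulforhodamine B assay, with a stated time of 48 h; on this read-out lower numbers stand for stronger inhibition and higher numbers for weaker inhibition. Compound 1 gives the lowest of the two numbers, and compound 2 sits close to it, a 1.3-fold higher number from compound 1 to compound 2 (0.10 log units; within the scatter). For compound 3 only a limit is reported, (the limit of > 1000 nM in this assay, at which 1 of the 3 values shown sits). The step is larger an at least 2.0-fold higher number from compound 1 to compound 3 (0.31 log units; beyond the scatter), while an at least 1.6-fold higher number from compound 2 to compound 3 (0.21 log units; that floor lies within the scatter). Compound 4 `Cc1cc(C)cc(NS(=O)(=O)c2ccc(N3CCNC3=O)cc2)c1` is not yet measured; it differs from compound 1 by 3,5-dimethylphenyl in place of 4-methylphenyl on a sulfonamide nitrogen. Among the compounds with values here, no measured step alters the phenyl in this way; the measured steps lengthen a chain on it, and the shorter lengthening stayed within the scatter. Compound 4 is therefore expected to stay within the scatter of its parent, a 1.3-fold higher number from compound 1 to compound 4 (0.10 log units; within the scatter). For compound 4 the estimate in this assay is 600 nM, with a range from 300 nM to 1200 nM.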

Compound 4, half-maximal inhibitory concentration: 82 nM
Beside the measured number, compound 4's estimate is 7.3-fold (0.86 log units) above it; measured number below the stated range.
By their numbers in this assay, from the lowest: compound 4; then compounds 1 and 2 (each within the scatter of the next). At a limit, above all of these: compound 3.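

In this assay, 3,5-dimethylphenyl in place of 4-methylphenyl on a sulfonamide nitrogen gives a 5.9-fold lower number from compound 1 to compound 4 (0.77 log units; beyond the scatter). The earlier compounds shown here only lengthened a chain on this phenyl, and none of those changes lowered the number beyond the scatter, so this position also admits a change that does. Nothing shown gives a cause for this step. The compounds shown leave open how an unsubstituted phenyl would read here. They also leave open whether ethyl, methoxy or chlorine could stand in for the two methyl groups of 3,5-dimethylphenyl.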